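The source may report more compounds than this note shows. Statements on the series, on what has been measured and on what is new or still open speak of the compounds shown alone.

Measured so far:
- compound 1 `Cc1cc(C)c(Oc2cc(Nc3ccc(C#N)cc3)c(N)cc2N)c(C)c1` — 50000 nM
- compound 2 `COc1ccc(Nc2cc(Oc3c(C)cc(C)cc3C)c([N+](=O)[O-])cc2[N+](=O)[O-])cc1` — > 59100 nM
- compound 3 `COc1ccc(Nc2cc(Oc3c(C)cccc3C)c([N+](=O)[O-])cc2[N+](=O)[O-])cc1` — > 61100 nM

Within the data shown here, in an ADME assay on H9 cells (Homo sapiens) for cytotoxicity, read by XTT assay, with a stated time of 6 days (a lower number here means that less compound is tolerated, a higher number that more compound is tolerated), compound 1 gives 50000 nM, the only number. For compound 2 the value > 59100 nM is a limit of the assay and not a number. For compound 3 the value > 61100 nM is likewise a limit. The step that the two limits leave unreadable from compound 2 to compound 3 cannot be read, due to the limit of > 59100 nM in this assay, at which 1 of the 3 values shown sits, and (the limit of > 61100 nM in this assay, at which 1 of the 3 values shown sits); the change behind it is hydrogen in place of methyl on an aromatic carbon.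

Compound 4 `Cc1cccc(C)c1Oc1cc(Nc2ccc(C#N)cc2)c(N)cc1N` is not yet measured. It differs from compound 1 by hydrogen in place of methyl on an aromatic carbon, the same change as from compound 2 to compound 3, at the same place. How the core of compound 1 differs from the core of compound 2 is not broken down here.

The one measured instance of the change gives no readable size, so nothing shown argues for a shift. The expectation rests on the value of compound 1, 50000 nM, and the step from compound 1 to compound 4 is expected to be about flat, no change at the digits printed from compound 1 to compound 4 (within the scatter). For compound 4 in this assay the estimate is 50000 nM, expected between 25000 nM and 100000 nM, with a fair chance that only a limit is reported, as for compound 2 and compound 3.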

Compound 4, half-maximal cytotoxic concentration: 53200 nM
Compound 4: the middle estimate sits 1.1-fold (0.03 log units) below what was measured; low and high end bracket the measured number.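

Working notes on the methyl change. In this assay, going from 2,4,6-trimethylphenyl to 2,6-dimethylphenyl on the core of compound 1 gives a 1.1-fold higher number from compound 1 to compound 4 (0.03 log units; within the scatter), so hydrogen in place of methyl at this carbon leaves the read-out flat on that core. For compound 2, the reported value is a limit of the assay and not a number: the limit of > 59100 nM in this assay, at which 1 of the 4 values shown sits. Among these compounds, for compound 3, the reported value is also a limit and not a number, so the same change on the second core cannot be read, and the one readable instance does not show that the result carries from one core to the other: the limit of > 61100 nM in this assay, at which 1 of the 4 values shown sits.

Still open, going by these compounds, is how this assay responds when an amine, a carboxylic acid or a longer chain takes the place of this methyl group, meta to two methyl groups and para to a large group. Also open, on these data alone, is what happens with hydrogen in place of the two methyl groups that remain in the 2,6-dimethylphenyl group, on either core.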